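The source may report more compounds than this note shows. Statements on the series, on what has been measured and on what is new or still open speak of the compounds shown alone.

Three compounds share the core of compound 1 `Cc1nc(Nc2ccccc2)c2cc[nH]c2n1`, which in a functional assay on the whole organism for inhibition, with Nicotiana tabacum as the target (a higher number here means a weaker inhibitor, a lower number a stronger inhibitor), gives 550000000 nM. Compound 2 `CCc1ccc(Nc2[nH]c(C)nc3nccc2-3)cc1` gives 214000000 nM, and compound 3 `Cc1nc(Nc2ccc(N)cc2)c2cc[nH]c2n1`, in which amino replaces hydrogen on an aromatic carbon, gives 195000000 nM. Compound 1 therefore stands highest of the three numbers: the gap to compound 2 is somewhat smaller than the gap to compound 3, and both lie beyond the usual scatter. The one step that joins two of these compounds in a single change is a 2.8-fold lower number from compound 1 to compound 3 (0.45 log units; beyond the scatter), a modest gain.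

Compound 4 `Cc1nc(Nc2ccc(C#N)cc2)c2cc[nH]c2n1` differs from compound 1 by cyano in place of hydrogen on an aromatic carbon. Among the measured compounds shown here, the only measured step that bears on this change is the one from compound 1 to compound 3, where a different group enters at the same kind of position and the number falls by a modest amount. The cyano group shares nothing with amino beyond its place on the ring, so its effect is largely unknown from these data. Compound 4 is expected to give 400000000 nM, between 150000000 nM and 1100000000 nM, meaning an expected step of a 1.4-fold lower number from compound 1 to compound 4 (0.14 log units; within the scatter) in this assay, within or only just beyond the scatter.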

Compound 4, half-maximal inhibitory concentration: 501000000 nM
Beside the measured number, compound 4's estimate is 1.3-fold (0.10 log units) below it; the range from low to high includes it.
By their numbers in this assay, from the lowest: compounds 3 and 2 (each within the scatter of the next); then compounds 4 and 1 (each within the scatter of the next).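

In this assay, cyano in place of hydrogen on an aromatic carbon, para to a large group, gives a 1.1-fold lower number from compound 1 to compound 4 (0.04 log units; within the scatter), so this change leaves the two compounds within the scatter of each other. Cyano in place of amino at the same place gives a 2.6-fold higher number from compound 3 to compound 4 (0.41 log units; beyond the scatter), a modest step beyond the scatter, which shows that the number at this position depends on the group that sits there and that, of the three groups seen so far, only amino sets its compound apart. Nothing available explains why amino and cyano differ here.

From the compounds shown here alone, whether a hydroxyl, a methoxy or a carboxylic acid at this place would go with amino or with cyano remains open. So does the outcome with a halogen such as chlorine, or with a longer chain.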